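The compounds below may be only part of what the source reports. "The series", "measured", "known", "first", "only" and "open" are said of these compounds alone.

Measured compounds in a functional assay on A549 cells (Homo sapiens) for cytotoxicity, read by MTT assay, with a stated time of 24 h; a higher number here means a weaker inhibitor, a lower number a stronger inhibitor:
- compound 1 `CCNC(=O)Cn1nc(N)c2c(C(F)(F)F)cc(-c3ccccc3)nc21`: 18800 nM
- compound 2 `Nc1nn(CC(=O)NCc2ccco2)c2nc(-c3ccccc3)cc(C(F)(F)F)c12`: 7700 nM
- compound 3 `Nc1nn(CC(=O)NC2CCCCC2)c2nc(-c3ccccc3)cc(C(F)(F)F)c12`: 2300 nM

Compound 1 stands highest of the three numbers; its nearest neighbour is compound 2, reached by a 2.4-fold lower number from compound 1 to compound 2 (0.39 log units; beyond the scatter), and the furthest is compound 3, reached by an 8.2-fold lower number from compound 1 to compound 3 (0.91 log units; beyond the scatter). Between those two, a 3.3-fold lower number from compound 2 to compound 3 (0.52 log units; beyond the scatter).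

Compound 4 `Nc1nn(CC(=O)N2CCCC2)c2nc(-c3ccccc3)cc(C(F)(F)F)c12` is not yet measured. Relative to compound 1 it carries pyrrolidin-1-yl in place of ethylamino on a carbonyl carbon. Within the data shown here, every measured step in this assay changes the substituent on the amide-type nitrogen and each lowers the number, but none of them replaces ethylamino with pyrrolidin-1-yl on the carbonyl carbon, so there is no step that matches this change directly; the three steps only show that this part of the shared core is tolerant of change without raising the number.

On that basis the estimated step is a 2.1-fold lower number from compound 1 to compound 4 (0.32 log units; beyond the scatter), a modest lowering. The estimated value for compound 4 in this assay is 9000 nM, within a range of 3000 nM to 25000 nM.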

Compound 4, half-maximal inhibitory concentration: 18700 nM
Compound 4: middle estimate off by 2.1-fold (0.32 log units), on the low side; the measured number falls inside the stated range.
By their numbers in this assay, from the lowest: compound 3; then compound 2; then compounds 4 and 1 (each within the scatter of the next).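

In this assay, among these compounds, pyrrolidin-1-yl in place of ethylamino on the carbonyl carbon is the first change here that leaves compound 1 without a clear shift (a 1.0-fold lower number from compound 1 to compound 4 (0.00 log units; within the scatter)). Compound 4 also stands apart from the two compounds with lower numbers (an 8.1-fold higher number from compound 3 to compound 4 (0.91 log units; beyond the scatter); a 2.4-fold higher number from compound 2 to compound 4 (0.39 log units; beyond the scatter)), so more heavy atoms on this carbonyl carbon do not alone go with a lower number, and keeping the amide hydrogen is not enough either, as compound 1 keeps it. No supporting data bear on this result.

Open, going by these compounds, is whether piperidin-1-yl, morpholin-4-yl or dimethylamino would track compound 4. Cyclohexyl(methyl)amino would test whether the lower number of compound 3 (2300 nM) survives without the amide hydrogen.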